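Swapping the ring on the shared core for a tert-butylphenyl

This account rests on a few compounds, and the source may have more. Where it says the series, first, only, none or still open, it means among the compounds named here.

Compound 1 `CCCCCCCc1nc(N)n(CC(=O)Nc2ccccc2)c1-c1ccccc1Br`: 7900 nM
Compound 2 `Nc1nc(CC2CCCC2)c(-c2ccccc2Br)n1CC(=O)Nc1ccccc1`: 61400 nM
Compound 3 `Nc1nc(CC2CCCCC2)c(-c2ccccc2Br)n1CC(=O)Nc1ccccc1`: 89000 nM

In a functional assay on MIA PaCa-2 cells (Homo sapiens) for antiproliferative activity, read by MTT assay, with a stated time of 48 h (on this read-out higher numbers stand for weaker inhibition and lower numbers for stronger inhibition), compound 3 gives the highest number of the three. The gap to compound 2 is small: a 1.4-fold higher number from compound 2 to compound 3 (0.16 log units; within the scatter). The gap to compound 1, which carries a hexyl chain where compound 3 carries a cyclohexyl, is large: an 11-fold higher number from compound 1 to compound 3 (1.05 log units; beyond the scatter), and compound 2 shows the same tendency in a 7.8-fold higher number from compound 1 to compound 2 (0.89 log units; beyond the scatter). So on these three compounds an open chain on the saturated chain carbon bound to an aromatic carbon goes with a markedly lower number than either saturated ring.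

Compound 4 `CC(C)(C)c1ccc(Cc2nc(N)n(CC(=O)Nc3ccccc3)c2-c2ccccc2Br)cc1` is built from compound 3 by the change (4-(tert-butyl)phenyl in place of cyclohexyl on a saturated chain carbon bound to an aromatic carbon). Among the compounds with values here, no measured step exchanges a saturated ring for an aromatic one, so the closest guide is only that this position tolerates clear shifts: the two ring compounds sit close together, while the chain compound sits well apart. An aromatic group of larger size is expected to move the number out of the range of the two saturated rings, most plausibly downward toward compound 1, but with wide uncertainty. For compound 4 the estimated value is 40000 nM, between 8000 nM and 150000 nM, meaning an expected step of a 2.2-fold lower number from compound 3 to compound 4 (0.35 log units; beyond the scatter).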

Compound 4, half-maximal inhibitory concentration: 4900 nM
Estimate against measurement, compound 4: 8.2-fold (0.91 log units) above, outside the stated range (below it).
By their numbers in this assay, from the lowest: compounds 4 and 1 (each within the scatter of the next); then compounds 2 and 3 (each within the scatter of the next).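

In this assay, a ring at this place, on a saturated chain carbon bound to an aromatic carbon, does not always go with a high number. Putting 4-(tert-butyl)phenyl in place of cyclohexyl gives a large drop (an 18-fold lower number from compound 3 to compound 4 (1.26 log units; beyond the scatter)), and putting it in place of cyclopentyl gives a similar one (a 13-fold lower number from compound 2 to compound 4 (1.10 log units; beyond the scatter)), so the high numbers of compound 2 and compound 3 belong to these two saturated rings and not to rings in general. Set against the hexyl chain, the same group makes no difference that can be read (a 1.6-fold lower number from compound 1 to compound 4 (0.21 log units; within the scatter)), which means the earlier contrast of open chain against ring holds only for the saturated rings, and nothing available explains why the aromatic group and the chain fall together.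

With a single aromatic group among these compounds, it remains open whether the lower number comes from the phenyl ring itself or from the tert-butyl on it, which a plain phenyl would help to separate. On these data alone, it is also open how a chain longer than hexyl, or a chain ending in an amine, would read at this place.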